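This account rests on a few compounds, and the source may have more. Where it says the series, first, only, none or still open, it means among the compounds named here.

Compound 1 `Nc1cc(N)c2nc(-c3ccccc3)c(Oc3ccc(Cl)c(Cl)c3)nc2c1` gives 12600 nM in a functional assay on 786-0 cells (Homo sapiens) for inhibition, read by sulforhodamine B assay, with a stated time of 48 h; a higher number here means a weaker inhibitor of growth, a lower number a stronger inhibitor of growth.
Compound 2 `COc1cc(CNc2nc3cc(N)cc(N)c3nc2-c2ccccc2)cc(OC)c1OC` gives 15500 nM in this assay.
Compound 3 `COc1ccc(CNc2nc3cc(N)cc(N)c3nc2-c2ccccc2)cc1` gives 15100 nM in this assay.

Compound 1 has the lowest number of the three, yet the values of compound 2 and compound 3 lie within the scatter of it, so the three cannot be ordered on these data. Compound 4 `Nc1cc(N)c2nc(-c3ccccc3)c(Sc3ccc(Cl)c(Cl)c3)nc2c1` differs from compound 1 in one place: (3,4-dichlorophenyl)sulfanyl in place of 3,4-dichlorophenoxy on an aromatic carbon. Among the measured compounds shown here, no pair of measured compounds shows a change of this kind, so the size of its effect in this assay has to be guessed; the expectation is a step no larger than the scatter, in either direction. Compound 4 is therefore expected to give about 10000 nM, with a range from 4000 nM to 25000 nM. For compound 4 this estimate amounts to an expected 1.3-fold lower number from compound 1 to compound 4 (0.10 log units; within the scatter).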

Compound 4, concentration for 50% growth inhibition: 23400 nM
Estimate against measurement, compound 4: 2.3-fold (0.37 log units) below, within the range that was stated.
By their numbers in this assay, from the lowest: compounds 1, 3, 2 and 4 (each within the scatter of the next).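

Among the compounds shown here, compound 4 gives the first one-place comparison in this assay: on the aromatic carbon next to the ring nitrogen, (3,4-dichlorophenyl)sulfanyl in place of 3,4-dichlorophenoxy gives a 1.9-fold higher number from compound 1 to compound 4 (0.27 log units; within the scatter). Sulfur and oxygen as the link to the dichlorophenyl ring therefore cannot be told apart at this position on these data. Nothing available explains the size of this step.

As far as these compounds go, whether a sulfonyl link or a simple amine on this carbon would move the number beyond the scatter remains open. So does the contribution of the two chlorine atoms on the phenyl ring.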